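From 6-methoxypyridin-3-yl to 1-methyl-1H-imidazol-4-yl in a small series

The compounds below may be only part of what the source reports. "The series", "measured", "known", "first", "only" and "open" are said of these compounds alone.

Compound 1 (`COc1ccc(-c2ccc(OC(F)(F)F)c(NC(=O)Nc3ccncc3)c2)cn1`) is the starting point of this step, yet it offers no number to work from. In a functional assay on SMMC-7721 cells (Homo sapiens) for inhibition, read by MTT assay, with a stated time of 48 h (a lower number here means a stronger inhibitor, a higher number a weaker inhibitor), compound 1 has no single result ("not determined" (no result reported)). The only figure available belongs to compound 2 (`COc1ccc(-c2ccc(OC(F)(F)F)c(NC(=O)Nc3nccs3)c2)cn1`), which differs from compound 1 elsewhere in the molecule. In this assay compound 2 gives a measured value (44100 nM).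

Compound 3 (`Cn1cnc(-c2ccc(OC(F)(F)F)c(NC(=O)Nc3ccncc3)c2)c1`) keeps the core of compound 1 and changes one group on an aromatic carbon: 1-methyl-1H-imidazol-4-yl in place of 6-methoxypyridin-3-yl, para to a trifluoromethoxy group (1-methyl-1H-imidazol-4-yl in place of 6-methoxypyridin-3-yl on an aromatic carbon).

With no number for compound 1, the size of this step in this assay cannot be read from the data. The working expectation is a step no larger than the scatter, with no direction favoured. Among the compounds with values here, the only anchor is therefore compound 2 (44100 nM), a single and indirect reference, so the range is kept wide. Compound 3 is estimated at 35000 nM in this measurement, with an expected range from 10000 nM to 100000 nM (a rough expectation only).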

Compound 3, half-maximal inhibitory concentration: > 300000 nM
Compound 3 ended at the assay's limit; the forecaster's own chance of this, stated with the estimate: 25%; middle value at least 8.5-fold (0.93 log units) away from the limit.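

Within the data shown here, no step from compound 1 to compound 3 can be read from these results. In this assay compound 3 gives > 300000 nM, which is a limit of the assay and not a number. The compounds shown leave open how far 1-methyl-1H-imidazol-4-yl in place of 6-methoxypyridin-3-yl shifts inhibition on the core of compound 1.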